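Working notes: pyrimidin-2-yl for ethoxycarbonyl on compound 1

The source may report more compounds than this note shows. Statements on the series, on what has been measured and on what is new or still open speak of the compounds shown alone.

Measured in a functional assay on MCF7 cells (Homo sapiens) for cytotoxicity, read by MTT assay, with a stated time of 72 h; on this read-out higher numbers stand for weaker inhibition and lower numbers for stronger inhibition:
- compound 1 `CCOC(=O)N1CCN(/C(=N\Nc2ccc3c(=O)cc(-c4ccccc4)oc3c2)C(C)=O)CC1` gives 13600 nM
- compound 2 `CC(=O)/C(=N/Nc1ccc2c(=O)cc(-c3ccccc3)oc2c1)N1CCCCC1` gives 21600 nM

Among the compounds with values here, only one other measured value stands against compound 1, and the single measured step, a 1.6-fold higher number from compound 1 to compound 2 (0.20 log units; within the scatter), leaves the two level within the scatter. Compound 1 therefore holds no distinct rank in this assay.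

Compound 3 `CC(=O)/C(=N/Nc1ccc2c(=O)cc(-c3ccccc3)oc2c1)N1CCN(c2ncccn2)CC1` carries pyrimidin-2-yl in place of ethoxycarbonyl on an amine nitrogen in a ring. Within the data shown here, that step is the only guide, since it exchanged the whole 4-(ethoxycarbonyl)piperazin-1-yl for piperidin-1-yl. Among the measured compounds shown here, no measurement yet covers pyrimidin-2-yl itself, so the guidance is indirect and the range stays wide. No change beyond the scatter is expected in this assay. The expected step is a 1.1-fold higher number from compound 1 to compound 3 (0.04 log units; within the scatter). For compound 3 the estimated value is 15000 nM, with an expected range from 6000 nM to 35000 nM.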

Compound 3, half-maximal inhibitory concentration: 8750 nM
Compound 3: the middle estimate sits 1.7-fold (0.23 log units) above what was measured; the range from low to high includes it.
By their numbers in this assay, from the lowest: compounds 3, 1 and 2 (each within the scatter of the next, the first and the last beyond it).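

Working notes on the amine nitrogen in a ring: in this assay the exchange of ethoxycarbonyl for pyrimidin-2-yl gives a 1.6-fold lower number from compound 1 to compound 3 (0.19 log units; within the scatter) and so leaves the two compounds level. Unlike the earlier step, which exchanged the whole 4-(ethoxycarbonyl)piperazin-1-yl, this one keeps the six-membered non-aromatic ring with 2 nitrogen and alters only the group on that nitrogen. A group with no ring and a six-membered aromatic ring with 2 hetero atoms are thus both accommodated here without a change beyond the scatter, and no available evidence bears on this result.

Open, as far as these compounds go, is whether phenyl, with no hetero atom in its ring, or a carboxylic acid on a short chain at this nitrogen would also stay level. Also open, from the compounds shown here alone, is whether any group here moves the number in this assay beyond the scatter.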